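Swapping the Side-Chain Acetate for a Hydroxyl

The source may report more compounds than this note shows. Statements on the series, on what has been measured and on what is new or still open speak of the compounds shown alone.

Measured so far in a functional assay on LUC1 cells (Homo sapiens) for cytotoxicity, read by sulforhodamine B assay, with a stated time of 48 h; on this read-out lower numbers stand for an effect already at smaller amounts and higher numbers for an effect only at larger amounts of compound:
Compound 1 `CCCC[C@@H](/C=C\[C@@H]1OC(=O)C=C[C@@H]1O)OC(C)=O` gives 2.3 ug/mL.
Compound 2 `CCCC[C@@H](/C=C\[C@@H]1OC(=O)C=C[C@@H]1OC(C)=O)OC(C)=O` gives 0.9 ug/mL.

Compound 2 holds the lowest of the two numbers shown, and its nearest neighbour is compound 1, separated by a 2.6-fold lower number from compound 1 to compound 2 (0.41 log units; beyond the scatter). That single step, the only one measured, concerns acetyl in place of hydrogen on an oxygen on a saturated carbon and runs toward a lower number.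

Compound 3 `CCCC[C@H](O)/C=C\[C@@H]1OC(=O)C=C[C@@H]1OC(C)=O` is the next compound. It differs from compound 2 in this way: hydrogen in place of acetyl on an oxygen on a saturated carbon. This is the reverse kind of exchange to the measured step, though at another oxygen on a saturated carbon, so the measured step bears on it only loosely. Taking that step as the sole guide, a modest rise in the number is expected, of size a 2.0-fold higher number from compound 2 to compound 3 (0.30 log units; within the scatter). Compound 3 is therefore estimated at 1.8 ug/mL in this assay, within 0.7 ug/mL to 4.5 ug/mL.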

Compound 3, concentration for half-maximal effect: 3.8 ug/mL
For compound 3 the middle estimate is 2.1-fold (0.32 log units) below the measured one; the range from low to high includes it.
By their numbers in this assay, from the lowest: compound 2; then compounds 1 and 3 (each within the scatter of the next).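

In this assay, going by these compounds alone, the acetoxy to hydroxy exchange on an oxygen on a saturated carbon whose other neighbours are saturated chain carbon gives a 4.2-fold higher number from compound 2 to compound 3 (0.63 log units; beyond the scatter) and so shows that the number at this position also responds to the loss of an acetyl group, which the earlier compounds could not show. Read with a 2.6-fold lower number from compound 1 to compound 2 (0.41 log units; beyond the scatter) at the other oxygen on a saturated carbon, the acetyl form gives the lower number at both oxygens in this small set, with no compound going against it. No evidence is at hand that accounts for this change.

Open, on these data alone, is how a compound with a free hydroxyl on both oxygens would read out. Also open, as far as these compounds go, is whether a longer acyl chain, a benzoyl group or a methyl ether at this oxygen would follow the acetyl or the hydrogen.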